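This account rests on a few compounds, and the source may have more. Where it says the series, first, only, none or still open, it means among the compounds named here.

Of the compounds shown here, three of one shared core have been tested, and only compound 1 `C=CCn1c(=O)/c(=C\c2cccc(C)c2)[nH]c(=O)/c1=C\c1ccccc1OC` carries a number: in a functional assay on MOLT-4 cells (Homo sapiens) for cytotoxicity, read by CCK-8 assay, with a stated time of 72 h (a higher number here means a weaker inhibitor, a lower number a stronger inhibitor), compound 1 gives 16000 nM. For compound 2 `COc1ccccc1/C=c1/[nH]c(=O)/c(=C\c2ccccc2OC)[nH]c1=O` the entry in this assay reads "not determined" (no result reported), so no result was reported, and compound 3 `C=CCn1c(=O)/c(=C\c2ccc(Cl)c(Cl)c2)[nH]c(=O)/c1=C\c1ccccc1` is recorded there as "not active" (no number reported), without a number. So compound 1 stands alone, with nothing to compare it to. Compound 4 `C=CCn1c(=O)/c(=C\c2cc(F)ccc2C)[nH]c(=O)/c1=C\c1ccccc1OC` differs from compound 1 in one place: 5-fluoro-2-methylphenyl in place of 3-methylphenyl on a double-bonded chain carbon bound to an aromatic carbon. Going by the values given here, no pair of measured compounds here differs in one place, so no measured step guides the expectation; the change is small and keeps one ring for one, and the step expected from compound 1 to compound 4 in this assay is no change at the digits printed from compound 1 to compound 4 (within the scatter), within the usual scatter. Compound 4 is thus expected to give about 16000 nM, between 6000 nM and 40000 nM.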

Compound 4, half-maximal inhibitory concentration: 3800 nM
Compound 4: middle estimate off by 4.2-fold (0.62 log units), on the high side, and the stated range ends above it.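

In this assay, putting 5-fluoro-2-methylphenyl in place of 3-methylphenyl on a double-bonded chain carbon bound to an aromatic carbon gives a 4.2-fold lower number from compound 1 to compound 4 (0.62 log units; beyond the scatter) in this series. Going by these compounds alone, this is the first readable step here, and it shows that the number responds to a small change at this position, one that still keeps one ring. Nothing measured here explains the step.

The two groups differ in both the fluorine and the methyl's place, and the compounds shown do not separate these two changes. Going by these compounds, how an amine or a carboxylic acid on this ring would fare also remains open.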